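Chloro next to the ring nitrogen on two related cores

The source may report more compounds than this note shows. Statements on the series, on what has been measured and on what is new or still open speak of the compounds shown alone.

Measured so far:
compound 1, `C#Cc1cncc(O[C@@H]2CCNC2)c1`, 62 nM
compound 2, `C#Cc1cc(O[C@@H]2CCNC2)cnc1Cl`, 46 nM
compound 3, `COc1cccc(-c2cncc(O[C@@H]3CCNC3)c2)c1`, 1120 nM

Among the measured compounds shown here, in an assay on a protein complex for binding affinity to Neuronal acetylcholine receptor; alpha4/beta2 (Rattus norvegicus) (on this read-out lower numbers stand for stronger inhibition and higher numbers for weaker inhibition), compound 1 gives 62 nM and compound 2 gives 46 nM; the single change between them is chloro in place of hydrogen on an aromatic carbon, and that step is a 1.3-fold lower number from compound 1 to compound 2 (0.13 log units; within the scatter). Compound 3 carries a different core, and the difference between the two cores is not broken down here. In this assay compound 3 gives 1120 nM, the highest of the three numbers.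

Compound 4, `COc1cccc(-c2cc(O[C@@H]3CCNC3)cnc2Cl)c1`, has not been measured. It differs from compound 3 by chloro in place of hydrogen on an aromatic carbon. For the measured compounds named here, this is the same kind of change as the one from compound 1 to compound 2: in both cases the chloro enters next to the ring nitrogen, but in compound 4 it sits ortho to a group of 8 heavy atoms and para to a (pyrrolidin-3-yl)oxy group, whereas in compound 2 it sits ortho to an ethynyl group and para to a group of 6 heavy atoms.

Going by the values given here, the one earlier example of this change stayed within the scatter, so compound 4 is expected to stay close to compound 3, with the step of a 1.2-fold lower number from compound 3 to compound 4 (0.09 log units; within the scatter). Because compound 3 gives 1120 nM, compound 4 is estimated at 900 nM, most likely between 350 nM and 2500 nM.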

Compound 4, half-maximal inhibitory concentration: 58 nM
For compound 4 the middle estimate is 16-fold (1.19 log units) above the measured one, and the stated range ends above it.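

In this assay, placing chloro on the aromatic carbon next to the ring nitrogen gives a 19-fold lower number from compound 3 to compound 4 (1.29 log units; beyond the scatter), a large step, so this small change can matter a great deal on the core of compound 3. Among the compounds shown here, the change therefore does not carry from one core to another at a fixed size, and a result on one core is a poor guide to the size of the step on the other: the same change on two cores in this assay, a 1.3-fold lower number (0.13 log units; within the scatter) from compound 1 to compound 2 and a 19-fold lower number (1.29 log units; beyond the scatter) from compound 3 to compound 4, 14-fold (1.16 log units) apart, beyond the scatter of two such steps What this does not show is why the two steps part, since only two pairs are available and their cores differ, with an ethynyl group on one and a group of 8 heavy atoms on the other, so no single feature of the core can be singled out as what sets the size of the step.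

From the compounds shown here alone, it remains open whether other groups in the same place, such as fluoro, bromo, methyl or an amine, would give a step as large as chloro on the core of compound 3. Going by these compounds, it also remains open whether the large step would hold if the group of 8 heavy atoms were replaced by a plain phenyl group or a longer chain.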